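Lactam amide series: aryl swap from compound 1 to compound 3

The compounds below may be only part of what the source reports. "The series", "measured", "known", "first", "only" and "open" are said of these compounds alone.

Measured so far:
compound 1, `O=C(COc1ccc(C(=O)/C=C/c2ccccc2Cl)cc1)N[C@H]1CCOC1=O`: 3240 nM
compound 2, `CC(C)c1ccc(NCC(=O)N[C@H]2CCOC2=O)cc1`: > 64000 nM, a limit, not a number

Within the data shown here, in a functional assay on DU-145 cells (Homo sapiens) for antiproliferative activity, read by MTT assay, with a stated time of 72 h (on this read-out lower numbers stand for stronger inhibition and higher numbers for weaker inhibition), compound 1 gives 3240 nM, the only plain number in the set. For compound 2 the result is a limit only, sitting at the limit of > 64000 nM in this assay, at which 1 of the 2 values shown sits. Compound 3, `O=C(COc1ccc(C(=O)/C=C/c2cccc(F)c2)cc1)N[C@H]1CCOC1=O`, differs from compound 1 by 3-fluorophenyl in place of 2-chlorophenyl on a double-bonded chain carbon bound to a double-bonded chain carbon. Among the measured compounds shown here, no measured pair carries this change, so its effect is unknown; the expected step of a 1.4-fold higher number from compound 1 to compound 3 (0.14 log units; within the scatter) is none beyond the scatter, if anything slightly toward weaker inhibition. Compound 3 is therefore estimated at 4500 nM, with a range from 1500 nM to 14000 nM.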

Compound 3, half-maximal inhibitory concentration: 17200 nM
Compound 3: middle estimate off by 3.8-fold (0.58 log units), on the low side; measured number outside the range, above it.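

In this assay, among these compounds, 3-fluorophenyl in place of 2-chlorophenyl on a double-bonded chain carbon bound to a double-bonded chain carbon gives a 5.3-fold higher number from compound 1 to compound 3 (0.72 log units; beyond the scatter), the first readable step. The aryl group at this place thus matters to the read-out, although both groups match in heavy-atom count and carry no hydrogen-bond donors or acceptors. No result shown gives a cause for this step.

From the compounds shown here alone, the identity of the halogen and its ring location change together here, so their separate contributions stay open. 2-Fluorophenyl and 3-chlorophenyl would separate them, and an aminophenyl group at the same place also remains open.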